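Lengthening the Sulfonyl Chain in a Legumain Inhibitor Series

This account rests on a few compounds, and the source may have more. Where it says the series, first, only, none or still open, it means among the compounds named here.

Compound 1 `CC(C)CS(=O)(=O)N(Cc1ccc(-c2cccc(F)c2)cc1)[C@@H](C)C(=O)N[C@H](C#N)CC(N)=O`: 2270 nM
Compound 2 `C[C@@H](C(=O)N[C@H](C#N)CC(N)=O)N(Cc1ccc(-c2cccc(F)c2F)cc1)S(=O)(=O)c1ccccc1`: > 10000 nM, a limit of the assay
Compound 3 `CCS(=O)(=O)N(Cc1ccc(-c2cccc(F)c2F)cc1)[C@@H](C)C(=O)N[C@H](C#N)CC(N)=O`: 1090 nM

All three were tested in an assay on isolated protein for inhibition of legumain (Homo sapiens), with stated times of 2 min and 60 min; a lower number here means a stronger inhibitor, a higher number a weaker inhibitor. For compound 2 this assay reports only a limit, (the limit of > 10000 nM in this assay, at which 1 of the 3 values shown sits), and not a number. Of the two numbers that were obtained, compound 3 has the lower one; compound 1 sits above it by more than the usual scatter, though the two differ in both the sulfonyl chain and the fluorine pattern on the outer ring, so no single change can be read from that pair.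

Among the measured compounds shown here, the one clean step concerns the group on the sulfonyl sulfur: an at least 9.1-fold lower number from compound 2 to compound 3 (0.96 log units; beyond the scatter).

Compound 4 `CC(C)CS(=O)(=O)N(Cc1ccc(-c2cccc(F)c2F)cc1)[C@@H](C)C(=O)N[C@H](C#N)CC(N)=O` keeps the core and the difluorinated ring of compound 3 and changes only the sulfonyl chain: isopropyl in place of methyl on a saturated chain carbon bound to a sulfonyl sulfur. For the measured compounds named here, no measured pair isolates this ethyl-to-isobutyl swap; the phenyl-to-ethyl step shows that this position matters, but it says nothing about growing the alkyl chain further. Compound 1 carries the isobutyl chain and is the weaker of the two numbered compounds, yet with a second difference attached.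

The expected step is therefore small, a 1.4-fold higher number from compound 3 to compound 4 (0.14 log units; within the scatter). Compound 4 is estimated at 1500 nM, within a range from 600 nM to 4000 nM.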

Compound 4, half-maximal inhibitory concentration: 1820 nM
The estimate for compound 4 lay 1.2-fold (0.08 log units) below the measured number; the range from low to high includes it.
By their numbers in this assay, from the lowest: compounds 3, 4 and 1 (each within the scatter of the next, the first and the last beyond it). At a limit, above all of these: compound 2.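

With the difluorinated ring held fixed, lengthening the chain on the sulfonyl sulfur from ethyl to isobutyl gives a 1.7-fold higher number from compound 3 to compound 4 (0.22 log units; within the scatter), and with the isobutyl chain held fixed, adding a fluoro group in place of hydrogen on an aromatic carbon gives a 1.2-fold lower number from compound 1 to compound 4 (0.10 log units; within the scatter), so in this assay neither single change can be told apart from the usual spread of repeated measurements. The advantage of an alkyl chain over phenyl on the sulfonyl sulfur is therefore not confined to ethyl, since isobutyl in place of phenyl gives an at least 5.4-fold lower number from compound 2 to compound 4 (0.73 log units; beyond the scatter). That step has only a lower bound on its size, as compound 2 gives a limit of the assay and not a number: the limit of > 10000 nM in this assay, at which 1 of the 4 values shown sits.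

With ethyl and isobutyl as the only alkyl chains on this sulfur, the compounds shown define no trend with chain length, and a longer chain such as n-hexyl could fall anywhere relative to them. They also leave open how a small ring such as cyclopropyl, or an amine or carboxylic acid at the end of the chain, would behave at this position.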